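Thiophen-3-yl for 3-fluorophenyl: no large step expected

The source may hold more compounds than are shown below. What is called first, only, known or untested is meant among the compounds shown, and "the series" means these compounds.

Measured so far in a functional assay on G-361 cells (Homo sapiens) for inhibition, with a stated time of 72 h; a higher number here means a weaker inhibitor, a lower number a stronger inhibitor:
Compound 1 `NC1CCC(Nc2nc(NCc3ccc(-c4ccccc4)cc3)c3ncn(C4CCCC4)c3n2)CC1`: 1020 nM
Compound 2 `COc1ccccc1-c1ccc(CNc2nc(NC3CCC(N)CC3)nc3c2ncn3C2CCCC2)cc1`: 545 nM
Compound 3 `NC1CCC(Nc2nc(NCc3ccc(-c4cccc(F)c4)cc3)c3ncn(C4CCCC4)c3n2)CC1`: 815 nM

Compound 3 is not separated from either of the other two compounds. The measured comparisons are a 1.3-fold lower number from compound 1 to compound 3 (0.10 log units; within the scatter) and a 1.5-fold higher number from compound 2 to compound 3 (0.17 log units; within the scatter). The next compound, compound 4 `NC1CCC(Nc2nc(NCc3ccc(-c4ccsc4)cc3)c3ncn(C4CCCC4)c3n2)CC1`, has not yet been measured. Its structure departs from that of compound 3 in one place: thiophen-3-yl in place of 3-fluorophenyl on an aromatic carbon. In words, this is thiophen-3-yl in place of 3-fluorophenyl on an aromatic carbon, para to a large group.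

Among the measured compounds shown here, three measured steps bear on this change, since each alters the group carried at that same place. Besides the two already given, there is a 1.9-fold lower number from compound 1 to compound 2 (0.27 log units; within the scatter). For the measured compounds named here, none of the three measured compounds carries thiophen-3-yl, and the data hold no direct example of this exchange. All three steps stay inside the scatter, and on that evidence no shift beyond the scatter is expected in this assay, in either direction. The expected change is a 1.0-fold lower number from compound 3 to compound 4 (0.01 log units; within the scatter). For compound 4 the estimated value is 800 nM, with an expected range of 380 nM to 1700 nM.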

Compound 4, half-maximal inhibitory concentration: 570 nM
Compound 4: middle estimate off by 1.4-fold (0.15 log units), on the high side; the range from low to high includes it.
By their numbers in this assay, from the lowest: compounds 2, 4, 3 and 1 (each within the scatter of the next).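

In this assay, thiophen-3-yl brings the first five-membered ring and the first sulfur to this place, on an aromatic carbon para to a large group, yet the result stays close to those of the six-membered rings: a 1.4-fold lower number from compound 3 to compound 4 (0.16 log units; within the scatter) and a 1.0-fold higher number from compound 2 to compound 4 (0.02 log units; within the scatter) and a 1.8-fold lower number from compound 1 to compound 4 (0.25 log units; within the scatter) all lie within the scatter. Among the compounds shown here, the four compounds, carrying phenyl, 2-methoxyphenyl, 3-fluorophenyl and thiophen-3-yl, therefore form one band with no pair separated, so this position has so far tolerated a change of ring size and of ring atoms as well as the substituents on phenyl seen earlier, without a shift that can be read. Nothing in the data gives a measured reason for this flat picture.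

For the compounds shown here, every group at this place so far is an aromatic ring, so it remains open whether a carboxylic acid, an aminomethyl chain or a saturated ring such as morpholine would leave this band. The compounds shown also keep the rest of the structure fixed, so they cannot tell whether the same flatness would hold with another group elsewhere on the shared core.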